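The compounds below may be only part of what the source reports. "The series", "measured", "known", "first", "only" and "open" are said of these compounds alone.

Working notes on the series. In an ADME assay on microsomes from liver (Canis lupus familiaris) for metabolic stability, read by LC-MS, using NADPH, with a stated time of 10 min, tested at 0.1 uM (on this read-out higher numbers stand for fast clearance and lower numbers for slow clearance), compound 1 `COc1ccccc1N1C(=O)CSC1c1cc(F)cc(C(=O)NCCCCc2ccccc2)c1` gives 2170 mL.min-1.g-1, compound 2 `C#Cc1cc(C(=O)NCCCCc2ccccc2)cc(C2SCC(=O)N2c2ccccc2OC)c1` gives 1750 mL.min-1.g-1 and compound 3 `Cc1cccc(N2C(=O)CSC2c2cccc(C(=O)NCCCCc3ccccc3)c2)c1` gives 749 mL.min-1.g-1. Compound 3 has the lowest number of the three, and its gap to each of the other two lies beyond the scatter.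

The next compound to consider is compound 4 `O=C(NCCCCc1ccccc1)c1cccc(C2SCC(=O)N2c2ccccn2)c1`, which has pyridin-2-yl in place of 3-methylphenyl on an amide-type nitrogen in a ring.

Among the compounds with values here, only one measured step links compounds that differ in one place: a 1.2-fold lower number from compound 1 to compound 2 (0.09 log units; within the scatter). That step is ethynyl in place of fluoro on an aromatic carbon. It lies within the scatter and concerns a different place from the present change, so it offers no direct guide to the size of this one. Within the data shown here, no measured pair covers a change on the amide-type nitrogen in a ring. The direction therefore rests on the structural change alone and remains uncertain, which calls for a wide range.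

A modest fall in this assay is expected, with the estimated step being a 1.8-fold lower number from compound 3 to compound 4 (0.25 log units; within the scatter). For compound 4 the estimated value is 420 mL.min-1.g-1, with an expected range from 170 mL.min-1.g-1 to 1000 mL.min-1.g-1.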

Compound 4, intrinsic clearance in microsomes: 492 mL.min-1.g-1
Compound 4: middle estimate off by 1.2-fold (0.07 log units), on the low side; the range from low to high includes it.
By their numbers in this assay, from the lowest: compounds 4 and 3 (each within the scatter of the next); then compounds 2 and 1 (each within the scatter of the next).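

In this assay, within the data shown here, the first measured step on the amide-type nitrogen in a ring is a 1.5-fold lower number from compound 3 to compound 4 (0.18 log units; within the scatter) for pyridin-2-yl in place of 3-methylphenyl, a change that lies within the scatter. At this position, then, a six-membered aromatic ring of carbon only can give way to one with a ring nitrogen and a hydrogen-bond acceptor, with no clearance difference that this pair can resolve, a point the earlier step on the aromatic carbon could not address. No supporting measurement is available to explain this result.

Still open, going by these compounds, is whether pyridin-3-yl, pyridin-4-yl, or a phenyl ring carrying an amine or a carboxylic acid on this same nitrogen would give a step beyond the scatter, as this single pair samples only one replacement for 3-methylphenyl. Also open, on these data alone, is whether the pyridin-2-yl change would give a similar step on the fluoro or ethynyl versions of the core, as in compound 1 and compound 2, where the group on this nitrogen is 2-methoxyphenyl.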